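This account rests on a few compounds, and the source may have more. Where it says the series, first, only, none or still open, it means among the compounds named here.

Working notes on the series in a functional assay on HeLa cells (Homo sapiens) for antiproliferative activity, read by MTT assay, with a stated time of 48 h; a lower number here means a stronger inhibitor, a higher number a weaker inhibitor. Among the measured compounds shown here, compound 3 `CCN(CC)CCCn1c(N)c(-c2nc3ccccc3[nH]2)c2nc(C#N)c(C#N)nc21` gives 3150 nM, the only actual number so far. Compound 1 `CCCn1c(N)c(-c2nc3ccccc3[nH]2)c2nc(C#N)c(C#N)nc21` reads > 50000 nM, which is a limit of the assay. Compound 2 `N#Cc1nc2c(-c3nc4ccccc4[nH]3)c(N)n(CCO)c2nc1C#N` reads > 50000 nM, also a limit.

The next entry is compound 4 `CCCCn1c(N)c(-c2nc3ccccc3[nH]2)c2nc(C#N)c(C#N)nc21`. Its difference from compound 3 is methyl in place of diethylamino on a saturated chain carbon, three bonds along the chain from an aromatic nitrogen, or 3-(diethylamino)propyl to butyl.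

The closest measured change is an at least 15-fold lower number from compound 1 to compound 3 (1.20 log units; beyond the scatter), where diethylamino replaces hydrogen in that same place. A second large change points the same way: an at least 15-fold lower number from compound 2 to compound 3 (1.20 log units; beyond the scatter). Both sizes are bounded by a limit at one end. The third measured change, a step that the two limits leave unreadable from compound 1 to compound 2, adds nothing.

Removing diethylamino should therefore reverse the direction, and a large rise is expected in this assay: a 13-fold higher number from compound 3 to compound 4 (1.10 log units; beyond the scatter) is the estimated step. For compound 4 the estimated value is 40000 nM, with an expected range of 12000 nM to 80000 nM, and a reading at the limit would not surprise.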

Compound 4, half-maximal inhibitory concentration: > 50000 nM
Compound 4: no number, only a limit; the forecaster's own chance of this, stated with the estimate: 65%; at least 1.2-fold (0.09 log units) between middle value and limit.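

In this assay, the change from 3-(diethylamino)propyl to butyl gives an at least 15-fold higher number from compound 3 to compound 4 (1.20 log units; beyond the scatter). The earlier steps shown here set diethylamino only against hydrogen or a hydroxy-bearing chain; with methyl on the same saturated chain carbon there is again no readable number, so among the four compounds only compound 3, the one carrying diethylamino, gives one. Compound 4 gives only a limit, its steps to compound 1 and compound 2 cannot be read, and the true size of its step from compound 3 stays bounded: the limit of > 50000 nM in this assay, at which 3 of the 4 values shown sit.

From the compounds shown here alone, whether this gain belongs to diethylamino itself or to any amine at the chain end remains open, with dimethylamino, pyrrolidine or a primary amine as the direct tests. Going by these compounds, the effect of a longer chain carrying the diethylamino group is also open.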